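Moving the fluoro group from compound 3 to compound 4

A few compounds are considered here, and "the series" means these few. Any claim that something is new, unique, unknown or untested is made for them only; others in the source may bear on it.

Compound 3 `NC(=O)c1nc(C#Cc2ccc(F)cc2)n(COCCO)n1` reads > 50 ug/mL in an ADME assay on Huh-5-2 cells (Homo sapiens) for cytotoxicity (a lower number here means that less compound is tolerated, a higher number that more compound is tolerated), which is a limit of the assay and not a number. Compound 1 `Cc1ccc(C#Cc2nc(C(N)=O)nn2COCCO)cc1` reads > 50 ug/mL, which is also a limit. Compound 2 `NC(=O)c1nc(C#Cc2ccc(C(F)(F)F)cc2)n(COCCO)n1`, which carries trifluoromethyl, gives a true number of 20 ug/mL.

Compound 4 `NC(=O)c1nc(C#Cc2ccccc2F)n(COCCO)n1` has the same atoms as compound 3, joined differently: 2-fluorophenyl in place of 4-fluorophenyl on a triple-bonded carbon. The change is 2-fluorophenyl in place of 4-fluorophenyl on a triple-bonded carbon.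

Within the data shown here, only two measured steps have a readable size, an at least 2.5-fold lower number from compound 1 to compound 2 (0.39 log units; beyond the scatter) and an at least 2.5-fold higher number from compound 2 to compound 3 (0.39 log units; beyond the scatter). Each lies beyond the scatter, and each involves trifluoromethyl, which compound 4 does not carry. The third, a step that the two limits leave unreadable from compound 1 to compound 3, cannot be sized. None of these steps moves a fluoro group from one place to another, so the evidence on this change is indirect.

No step beyond the scatter is therefore expected in this assay, and a further reading at the limit is the likelier outcome. That expectation rests on compound 3 and its limit of > 50 ug/mL. The estimated step is a number no higher from compound 3 to compound 4 (the limit leaves the size open). For compound 4 the estimated value is 50 ug/mL, with an expected range from 22 ug/mL to 100 ug/mL.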

Compound 4, half-maximal cytotoxic concentration: > 50 ug/mL
Compound 4: no number, only a limit (the forecaster's own chance of this, stated with the estimate: 65%); the middle value sits exactly at the limit.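

In this assay compound 4 reads > 50 ug/mL, which is a limit of the assay and not a number. Neither the step from compound 3 to compound 4 nor the step from compound 1 to compound 4 can be read, because both ends of each stand at the same limit: the limit of > 50 ug/mL in this assay, at which 3 of the 4 values shown sit.

The compounds shown leave open whether 2-fluorophenyl in place of 4-fluorophenyl changes the tolerated concentration at all.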